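Swapping the Sulfonyl Aryl Group: What to Expect

This account rests on a few compounds, and the source may have more. Where it says the series, first, only, none or still open, it means among the compounds named here.

Measured so far, in a functional assay on A549 cells (Homo sapiens) for antiproliferative activity, read by MTT assay, with a stated time of 72 h; on this read-out higher numbers stand for weaker inhibition and lower numbers for stronger inhibition:
compound 1 `CN(C(=O)CCc1ccccc1)c1ccc2[nH]c(-c3n[nH]c4ccccc34)cc2n1` gives 18100 nM;
compound 2 `Cc1ccc(S(=O)(=O)N(C)c2ccc3[nH]c(-c4n[nH]c5ccccc45)cc3n2)cc1` gives 27100 nM.

Both compounds share one core and differ only in the group on the ring nitrogen. Compound 2 sits beside compound 1 rather than apart from it: the step of a 1.5-fold higher number from compound 1 to compound 2 (0.18 log units; within the scatter) is within the scatter, so the two numbers cannot be told apart on the evidence shown.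

Compound 3 `COc1ccc(S(=O)(=O)N(C)c2ccc3[nH]c(-c4n[nH]c5ccccc45)cc3n2)cc1OC` has not yet been measured. It differs from compound 2 in one place: 3,4-dimethoxyphenyl in place of 4-methylphenyl on a sulfonyl sulfur. Going by the values given here, no measured step touches this position. Among the compounds with values here, the only step available, the one from compound 1 to compound 2, replaced the whole group on the nitrogen and produced no change beyond the scatter. There is therefore nothing in the measured data pointing to a shift of any size in either direction, and the plain expectation is a number close to that of compound 2.

Compound 3 is expected at 25000 nM, with a range from 8000 nM to 80000 nM. The expected step of a 1.1-fold lower number from compound 2 to compound 3 (0.04 log units; within the scatter) lies within the scatter.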

Compound 3, half-maximal inhibitory concentration: > 50000 nM
Compound 3 gave a limit, no number; the forecaster's own chance of this, stated with the estimate: 10%; at least 2.0-fold (0.30 log units) between middle value and limit.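

Going by these compounds alone, the aryl group on the sulfonyl sulfur is changed here for the first time, and in this assay replacing 4-methylphenyl with 3,4-dimethoxyphenyl gives an at least 1.8-fold higher number from compound 2 to compound 3 (0.26 log units; that floor lies within the scatter). That step is only a floor, so on its own it does not separate the two compounds: the true gap could lie within the usual scatter or be far larger, and no size can be assigned to it. The result for compound 3 is a limit of the assay and not a number, so the position has now been probed once, with no sign of stronger inhibition from the two methoxy groups, and the reading stops here: the limit of > 50000 nM in this assay, at which 1 of the 3 values shown sits.

The compounds shown leave open whether one methoxy group alone on the phenyl ring would read like compound 2 or like compound 3, and so which part of the change matters. They also leave open how this position would respond to a different kind of group on the phenyl ring, such as an amine or a carboxylic acid, which could show whether any change here can strengthen inhibition.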